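Amino group added to compound 2

The compounds below may be only part of what the source reports. "The series", "measured", "known", "first", "only" and "open" are said of these compounds alone.

- compound 1 `Cn1ncc2c(NS(=O)(=O)c3cccc(Cl)c3Cl)ncnc21`: 476000 nM
- compound 2 `COc1nn(C)c2ncnc(NS(=O)(=O)c3cccc(Cl)c3Cl)c12`: >= 581000 nM
- compound 3 `COc1nn(C2COC2)c2ncnc(NS(=O)(=O)c3cccc(Cl)c3Cl)c12`: 142000 nM

These three values come from a physicochemical assay for solubility, read by chemiluminescence, measured as kinetic solubility; on this read-out lower numbers stand for lower solubility and higher numbers for higher solubility. From the compounds shown here alone, compound 2 stands at the limit of >= 581000 nM in this assay, at which 1 of the 3 values shown sits, which is a limit and not a number, so its exact place among the three stays open.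

Compound 4 `COc1nn(C)c2nc(N)nc(NS(=O)(=O)c3cccc(Cl)c3Cl)c12` departs from compound 2 by one change: amino in place of hydrogen on an aromatic carbon, on an aromatic carbon between two ring nitrogen atoms. The closest measured change is methoxy in place of hydrogen on an aromatic carbon, which gave an at least 1.2-fold higher number from compound 1 to compound 2 (0.08 log units; that floor lies within the scatter). The other change, oxetan-3-yl in place of methyl on an aromatic nitrogen, is less alike and gave an at least 4.0-fold lower number from compound 2 to compound 3 (0.61 log units; beyond the scatter). That second step is the only one beyond the scatter, and it points downward, so a small move down is expected here, if any. The expected size is an at least 1.6-fold lower number from compound 2 to compound 4 (0.22 log units; that floor lies within the scatter) in this assay. For compound 4 the estimated value is 350000 nM, with an expected range from 120000 nM to 700000 nM.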

Compound 4, solubility: >= 649000 nM
Compound 4: a limit, no number; the forecaster's own chance of this, stated with the estimate: 30%; middle value at least 1.8-fold (0.26 log units) from the limit.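

In this assay compound 4 gives >= 649000 nM, which is a limit and not a number. Among these compounds, compound 2 gives >= 581000 nM, also a limit, so no step between compound 2 and compound 4 can be read. From the compounds shown here alone, whether amino in place of hydrogen on that aromatic carbon moves the read-out up or down, and by how much, stays open.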